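This account rests on a few compounds, and the source may have more. Where it says the series, first, only, none or still open, it means among the compounds named here.

Working notes on the series. Compound 1 `Cc1ccccc1OCC1=NCCO1` gives 20% in a toxicity assay on the whole organism with Rattus norvegicus as the target, at a dose of 200 mg/kg by the oral route; on this read-out lower numbers stand for a weaker effect and higher numbers for a stronger effect at the one dose given. Compound 2 `Cc1cccc(OCC2=NCCO2)c1` gives 20% in this assay, and compound 3 `Cc1ccc(OCC2=NCCO2)c(C)c1` gives 25% in this assay. Compound 1 stands level with compound 2 at the digits shown, the two together the lowest of the three numbers, and the step of a number 5 percentage points higher from compound 1 to compound 3 (within the scatter) lies within the scatter.

Compound 4 `Fc1ccccc1OCC1=NCCO1` differs from compound 1 by fluoro in place of methyl on an aromatic carbon. Among the measured compounds shown here, no measured step exchanges methyl for fluoro. For the measured compounds named here, the only measured step, a number 5 percentage points higher from compound 1 to compound 3 (within the scatter), adds a methyl and stays within the scatter, so no step beyond the scatter is expected for compound 4 in this assay. Compound 4 is therefore expected at 20%, with a range of 10% to 35%. The expected step is no change at the digits printed from compound 1 to compound 4 (within the scatter).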

Compound 4, a percentage reported as activity, at one dose (the size of the read-out at that dose, not a potency): 15%
Beside the measured number, compound 4's estimate is 5 percentage points above it, and the stated range covers the measured number.
By their numbers in this assay, from the lowest: compounds 4, 1, 2 and 3 (each within the scatter of the next).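

Fluoro in place of methyl on an aromatic carbon, ortho to a group of 7 heavy atoms, gives a number 5 percentage points lower from compound 1 to compound 4 (within the scatter) in this assay. Among the compounds shown here, this is the first measured exchange of the methyl itself at this position, and one heavy atom for another here leaves the number within the scatter of compound 1. No measured evidence bears on this result, so it comes with no explanation.

As far as these compounds go, an amine, a carboxylic acid or a longer chain on that same carbon remains open in this assay. So does fluoro on another carbon of the aromatic ring.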